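Exchanging one oxygen-bearing group on a shared core

This account rests on a few compounds, and the source may have more. Where it says the series, first, only, none or still open, it means among the compounds named here.

In a functional assay on SH-SY5Y cells (Homo sapiens) for cytotoxicity, read by MTT assay, with a stated time of 72 h (on this read-out higher numbers stand for weaker inhibition and lower numbers for stronger inhibition), compound 1 `O=C1c2c[n+]([O-])c3ccccc3c2C(=O)c2c1c1ccccc1n2Cc1cn([C@H]2O[C@H](CO)[C@@H](O)[C@H]2O)nn1` gives 1340 nM. That is the middle of three measured numbers, since compound 2 `CN1CCN(CCCCn2c3c(c4ccccc42)C(=O)c2c[n+]([O-])c4ccccc4c2C3=O)CC1` gives 100 nM and compound 3 `CCCCN1CCN(CCCCn2c3c(c4ccccc42)C(=O)c2c[n+]([O-])c4ccccc4c2C3=O)CC1` gives 6100 nM.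

Compound 4 `CC1(C)OC[C@H](Cn2cc(Cn3c4c(c5ccccc53)C(=O)c3c[n+]([O-])c5ccccc5c3C4=O)nn2)O1` has not yet been measured. It carries (2,2-dimethyl-1,3-dioxolan-4-yl)methyl in place of 3,4-dihydroxy-5-(hydroxymethyl)oxolan-2-yl on an aromatic nitrogen of the core of compound 1: (2,2-dimethyl-1,3-dioxolan-4-yl)methyl in place of 3,4-dihydroxy-5-(hydroxymethyl)oxolan-2-yl on an aromatic nitrogen.

Within the data shown here, only one measured step exists, a 61-fold higher number from compound 2 to compound 3 (1.79 log units; beyond the scatter), and it lies at another place in the molecule. It shows that a single change in this small set can be large, but it says nothing about this exchange or its direction. A wide range is therefore warranted, with no lean to either side beyond a slight one. The expected change is a 1.1-fold lower number from compound 1 to compound 4 (0.05 log units; within the scatter). Compound 4 is estimated at 1200 nM, with an expected range from 300 nM to 5000 nM.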

Compound 4, half-maximal inhibitory concentration: 820 nM
For compound 4 the middle estimate is 1.5-fold (0.17 log units) above the measured one, and the stated range covers the measured number.
By their numbers in this assay, from the lowest: compound 2; then compounds 4 and 1 (each within the scatter of the next); then compound 3.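

In this assay, the exchange on the aromatic nitrogen gives a 1.6-fold lower number from compound 1 to compound 4 (0.21 log units; within the scatter), so at this position the two oxygen-bearing groups are not told apart by the read-out. Among these compounds, this holds even though the entering (2,2-dimethyl-1,3-dioxolan-4-yl)methyl has 0 hydrogen-bond donors and 1 defined stereocentre, where the leaving 3,4-dihydroxy-5-(hydroxymethyl)oxolan-2-yl has 3 and 4, and it contrasts with the only earlier step, at another place, a 61-fold higher number from compound 2 to compound 3 (1.79 log units; beyond the scatter). No measurement shown accounts for this result.

Going by these compounds, whether an amine, a carboxylic acid or a longer chain on this aromatic nitrogen would also stay within the scatter of compound 1 remains open. So does the reading of a 2,3-dihydroxypropyl group at the same place, which would carry free hydroxyl groups on an open chain.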